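Ester to alcohol on the side-chain-bearing core

This account rests on a few compounds, and the source may have more. Where it says the series, first, only, none or still open, it means among the compounds named here.

Compound 2 `CCOC(=O)c1cc2cc(OCCCC3CCN(Cc4ccccc4)CC3)ccc2n1C` carries an ethoxycarbonyl group on the shared core. In an assay on isolated protein for inhibition of Amine oxidase [flavin-containing] B (Homo sapiens), read by fluorescence, with stated times of 30 min and 1 h (a higher number here means a weaker inhibitor, a lower number a stronger inhibitor), compound 2 gives only the limit of the assay, > 100000 nM. Compound 1 `COc1ccc2c(c1)cc(C(=O)NCc1ccccc1)n2C` lacks the long side chain of the rest of the set; in this assay compound 1 likewise gives only the limit, > 100000 nM. Compound 3 `Cn1c(C(=O)N2CCOCC2)cc2cc(OCCCC3CCN(Cc4ccccc4)CC3)ccc21` has a morpholine amide in place of the ester; in this assay compound 3 again gives no number but the limit, > 100000 nM. Among the compounds with values here, compound 2 therefore stands exactly where every other measured member stands, and the single step between measured compounds, a step that the two limits leave unreadable from compound 2 to compound 3, cannot be read because the limit of > 100000 nM in this assay, at which 3 of the 3 values shown sit, caps both of its ends.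

Compound 4 `Cn1c(CO)cc2cc(OCCCC3CCN(Cc4ccccc4)CC3)ccc21` differs from compound 2 by hydroxymethyl in place of ethoxycarbonyl on an aromatic carbon. Within the data shown here, no measured step bears directly on this change; the one variation at the same carbon that was measured left both partners at the limit, so there is nothing to point toward a shift beyond the scatter. The expected step is a step that the limit leaves unreadable from compound 2 to compound 4, with the outcome most likely another limit. For compound 4 the estimate in this assay is 150000 nM, within a range from 30000 nM to 1000000 nM.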

Compound 4, half-maximal inhibitory concentration: > 100000 nM
Compound 4 gave a limit, no number; the forecaster's own chance of this, stated with the estimate: 85%; the middle value lies beyond the limit too.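

In this assay compound 4 gives > 100000 nM as a limit, not a number. The steps to compound 4 from compound 2 and from compound 3 therefore cannot be read, and no new comparison follows from this result. The compounds shown leave open whether any change on the shared core gives a measurable inhibition in this assay at all.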